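Rearranging the Ring Pair on the Ether Oxygen

This account rests on a few compounds, and the source may have more. Where it says the series, first, only, none or still open, it means among the compounds named here.

Compounds measured so far:
compound 1 `Cc1cc(=O)n(-c2ccccc2OC(F)(F)F)nc1C(=O)Nc1ccc(Oc2ncnc3ccsc23)c(F)c1`, which in a functional assay on MCF7 cells (Homo sapiens) for cytotoxicity, read by MTT assay, with a stated time of 72 h (a lower number here means a stronger inhibitor, a higher number a weaker inhibitor), gives 11500 nM
compound 2 `Cc1ccc(-n2nc(C(=O)Nc3ccc(Oc4ncnc5ccsc45)c(F)c3)c(C)cc2=O)cc1`, which gives 7250 nM

Compound 1 has the larger of the two numbers shown, with compound 2 nearest to it; the step of a 1.6-fold lower number from compound 1 to compound 2 (0.20 log units; within the scatter) separates them. Compound 3 `Cc1cc(=O)n(-c2ccccc2OC(F)(F)F)nc1C(=O)Nc1ccc(Oc2ncnc3sccc23)c(F)c1` has not yet been measured. It differs from compound 1 by a group of 9 heavy atoms (6 carbon, 2 nitrogen, 1 sulfur; one five-membered aromatic ring with 1 hetero atom, one six-membered aromatic ring with 2 hetero atoms) in place of a group of 9 heavy atoms (6 carbon, 2 nitrogen, 1 sulfur; one five-membered aromatic ring with 1 hetero atom, one six-membered aromatic ring with 2 hetero atoms), on an oxygen on an aromatic ring; the two compounds have the same atoms, joined differently. Going by the values given here, no measured step touches this part of the molecule: the only step available, a 1.6-fold lower number from compound 1 to compound 2 (0.20 log units; within the scatter), exchanges the group on the aromatic nitrogen at the far end and stays within the scatter. The measurements therefore give no guide to what a rearrangement on the ether oxygen does, and the expectation is a step no larger than the scatter, no change at the digits printed from compound 1 to compound 3 (within the scatter). Compound 3 is accordingly estimated at 11500 nM, within a range from 4000 nM to 35000 nM.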

Compound 3, half-maximal inhibitory concentration: > 40000 nM
Compound 3 ended at the assay's limit; the forecaster's own chance of this, stated with the estimate: 10%; middle value at least 3.4-fold (0.54 log units) away from the limit.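

Going by these compounds alone, the group on the ether oxygen matters, which the earlier compounds could not show. In this assay, within the data shown here, rejoining the same atoms in this group gives an at least 3.4-fold higher number from compound 1 to compound 3 (0.54 log units; beyond the scatter), whereas the only earlier step, an exchange on the aromatic nitrogen, gave a 1.6-fold lower number from compound 1 to compound 2 (0.20 log units; within the scatter). Compound 3 sits at a limit of the assay and not at a number, so the true size of its step is not known: the limit of > 40000 nM in this assay, at which 1 of the 3 values shown sits.

As far as these compounds go, it remains open whether a simpler group on the ether oxygen, such as a plain phenyl ring or a pyridine ring, would keep the value of compound 1, and whether the same rearrangement would have a similar effect with the 4-methylphenyl group of compound 2. The compounds shown also include no measurement that explains why joining the same atoms differently changes the result.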